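The compounds below may be only part of what the source reports. "The series", "measured", "known", "first", "only" and "open" are said of these compounds alone.

Measured compounds:
compound 1 `[SeH]c1nc2ccccc2s1`: > 50000 nM
compound 2 `O=C1c2ccccc2C(=O)N1CS`: > 100000 nM

In a functional assay on MCF7 cells (Homo sapiens) for cytotoxicity, read by MTT assay, with a stated time of 72 h (on this read-out higher numbers stand for weaker inhibition of growth and lower numbers for stronger inhibition of growth), compound 2 gives > 100000 nM, which is a limit of the assay and not a number. Compound 1 gives > 50000 nM in this assay, likewise a limit. Compound 3 `O=C1c2ccccc2C(=O)N1C[SeH]` differs from compound 2 by one selenium atom in place of one sulfur atom, on a saturated chain carbon bound to an amide-type nitrogen in a ring. Going by the values given here, no measured step exists; with compound 2 at the limit of > 100000 nM in this assay, at which 1 of the 2 values shown sits, and compound 1 at the limit of > 50000 nM in this assay, at which 1 of the 2 values shown sits, no step beyond the scatter is expected in this assay in either direction. Compound 3 is estimated at 100000 nM, range 30000 nM to 300000 nM. The expected step is a number no higher from compound 2 to compound 3 (the limit leaves the size open).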

Compound 3, concentration for 50% growth inhibition: 6000 nM
Compound 3: the middle estimate sits 17-fold (1.22 log units) above what was measured, and the stated range ends above it.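

In this assay, one selenium atom in place of one sulfur atom, on a saturated chain carbon bound to an amide-type nitrogen in a ring, gives an at least 16-fold lower number from compound 2 to compound 3 (1.22 log units; beyond the scatter). Going by these compounds alone, this is the first sign that this position can respond to the change, and compound 3 gives the first value that is not a limit, 6000 nM. The step has a limit at one end, that of compound 2: the limit of > 100000 nM in this assay, at which 1 of the 3 values shown sits.

On these data alone, the full size of the step remains open. Also open, as far as these compounds go, is whether the selenium atom keeps this value on a longer chain, or with an amine or a carboxylic acid on the core.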